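The source may report more compounds than this note shows. Statements on the series, on what has been measured and on what is new or still open speak of the compounds shown alone.

Compound 1 `COc1ccccc1-c1csc2cnc(Nc3ccc(C(=O)NC4CCNCC4)c(C)c3)nc12`: 870 nM
Compound 2 `CNC(=O)c1ccc(Nc2ncc3scc(-c4ccccc4OC)c3n2)cc1`: 310 nM
Compound 3 `COc1ccccc1-c1csc2cnc(Nc3ccc(C(=O)NC4CCNCC4)cc3C(F)(F)F)nc12`: 4110 nM

These three compounds were tested in a functional assay on A549 cells (Homo sapiens) for inhibition, read by MTT assay, with a stated time of 72 h; a higher number here means a weaker inhibitor, a lower number a stronger inhibitor. Compound 3 stands highest at 4110 nM, and its gaps to the other two lie beyond the scatter. Compound 4 `COc1ccccc1-c1csc2cnc(Nc3ccc(C(=O)NC4CCNCC4)cc3)nc12` differs from compound 3 by one change, hydrogen in place of trifluoromethyl on an aromatic carbon. For the measured compounds named here, no measured pair isolates this change, so the expectation rests on indirect evidence. Neither compound 1 at 870 nM nor compound 2 at 310 nM carries trifluoromethyl, and both show lower numbers. A lower number beyond the scatter is therefore expected, an estimated 6.9-fold lower number from compound 3 to compound 4 (0.84 log units; beyond the scatter). The estimate for compound 4 is 600 nM, with an expected range of 200 nM to 1800 nM.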

Compound 4, half-maximal inhibitory concentration: 360 nM
Compound 4: the middle estimate sits 1.7-fold (0.22 log units) above what was measured, within the range that was stated.
By their numbers in this assay, from the lowest: compounds 2 and 4 (each within the scatter of the next); then compound 1; then compound 3.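

In this assay, for the compounds shown here, hydrogen in place of trifluoromethyl on this aromatic carbon gives an 11-fold lower number from compound 3 to compound 4 (1.06 log units; beyond the scatter) and so measures this change directly for the first time, while hydrogen in place of methyl on an aromatic carbon gives the smaller 2.4-fold lower number from compound 1 to compound 4 (0.38 log units; beyond the scatter) on the same ring. On the amide-type nitrogen, piperidin-4-yl in place of methyl gives a 1.2-fold higher number from compound 2 to compound 4 (0.06 log units; within the scatter) and so separates nothing here. No measurement offered here accounts for these steps.

The compounds shown leave open how fluorine, chlorine, a methoxy group or an amine on this carbon would compare with hydrogen.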